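This account rests on a few compounds, and the source may have more. Where it says the series, first, only, none or still open, it means among the compounds named here.

Measured in an ADME assay on Vero cells (Chlorocebus sabaeus) for cytotoxicity, read by neutral red uptake, with a stated time of 3 days; on this read-out lower numbers stand for higher toxicity in this test and higher numbers for lower toxicity in this test:

- Compound 1 `CC(C)n1ncc2c(C(=O)NCCN3CCCC3)cc(C3CC3)nc21`: 63100 nM
- Compound 2 `CCN(CC)CCNC(=O)c1cc(C2CC2)nc2c1cnn2C(C)C`: 53600 nM
- Compound 3 `CC(C)n1ncc2c(C(=O)NCCCN(C)C)cc(C3CC3)nc21`: > 200000 nM

Compound 3 gives > 200000 nM, which is a limit of the assay and not a number. Its place among the readings is the limit of > 200000 nM in this assay, at which 1 of the 3 values shown sits.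

The next compound to be tested is compound 4 `CNCCCNC(=O)c1cc(C2CC2)nc2c1cnn2C(C)C`. It differs from compound 3 by hydrogen in place of methyl on an amine nitrogen, so that dimethylamino becomes methylamino.

Among the measured compounds shown here, no measured step makes this exact change, but all three alter the same amine end of the chain, so they are the nearest guide. One of them stays within the scatter: a 1.2-fold lower number from compound 1 to compound 2 (0.07 log units; within the scatter). The two others go beyond it: an at least 3.1-fold higher number from compound 1 to compound 3 (0.50 log units; beyond the scatter) and an at least 3.7-fold higher number from compound 2 to compound 3 (0.57 log units; beyond the scatter). These show that this assay can respond to changes at this end, though each of them swaps a larger piece than a single methyl. Compound 4 keeps the rest of compound 3 unchanged, so a reading close to that of compound 3 seems the likeliest outcome, with some room towards compound 1 and compound 2.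

The expected change is an at least 1.3-fold lower number from compound 3 to compound 4 (0.12 log units; that floor lies within the scatter), and no step beyond the scatter is expected. For compound 4 the estimated value is 150000 nM, with an expected range from 60000 nM to 300000 nM.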

Compound 4, half-maximal cytotoxic concentration: 281000 nM
Beside the measured number, compound 4's estimate is 1.9-fold (0.27 log units) below it; measured number inside the range.
By their numbers in this assay, from the lowest: compounds 2 and 1 (each within the scatter of the next); then compound 4.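

The step from compound 3 to compound 4, hydrogen in place of methyl on an amine nitrogen, cannot be read, because compound 3 sits at a limit of the assay and not at a number: the limit of > 200000 nM in this assay, at which 1 of the 4 values shown sits.

What compound 4 adds is a real number at this end of the chain, one that can be set against the two lower readings in this assay. With methylamino at the chain end there is a 5.2-fold higher number from compound 2 to compound 4 (0.72 log units; beyond the scatter), and there is also a 4.5-fold higher number from compound 1 to compound 4 (0.65 log units; beyond the scatter). Both steps lie beyond the scatter, so a small amine end with a hydrogen on its nitrogen stays on the low-toxicity side of this test, clear of the diethylamino and pyrrolidin-1-yl compounds, and this side no longer rests on a limit alone.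

On these data alone, whether taking away the last methyl to leave a plain primary amine, or using a longer chain before the amine, would keep this reading remains open. Among the compounds shown here, the direction of the single methyl change itself also stays unknown, and only a number for compound 3 could settle it.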